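Adding a Cyclohexyl Ring to a Full Histamine Agonist

A few compounds are considered here, and "the series" means these few. Any claim that something is new, unique, unknown or untested is made for them only; others in the source may bear on it.

Compound 1 `N=C(NCCCc1c[nH]cn1)NCCC(c1ccccc1)c1ccccn1`, compound 2 `N=C(NCCCc1c[nH]cn1)NCCCC(c1ccccc1)c1ccccn1` and compound 3 `Cc1ccc(CC(CC/N=C(\N)NCCCc2c[nH]cn2)c2ccccn2)cc1` share one core and differ only in the chain bearing the two aromatic rings. In an assay on cardiac atrium with histamine H2 receptor (Cavia porcellus) as the target (on this read-out lower numbers stand for smaller maximal responses and higher numbers for larger maximal responses), compound 1 gives 1, compound 2 gives 1 and compound 3 gives 1. These values lie within the scatter of one another, so compound 3 stands level with both neighbours, each matching the reference agonist.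

Compound 4 `Cc1ccc(CC(CC/N=C(/NCCCc2c[nH]cn2)NC2CCCCC2)c2ccccn2)cc1` differs from compound 3 in one place: cyclohexyl in place of hydrogen on an amine nitrogen. For the measured compounds named here, no measured pair shows this change. Every measured compound carries hydrogen on that nitrogen, so the expectation rests on compound 3 alone. A drop beyond the scatter is expected, a number 0.30 lower from compound 3 to compound 4 (beyond the scatter). Compound 4 is therefore expected to reach 0.7 in this assay, within 0.4 to 1.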

Compound 4, intrinsic activity: the largest response reached, as a fraction of the reference agonist's: 1
Compound 4: middle estimate off by 0.30, on the low side, and the stated range covers the measured number.
By their numbers in this assay, from the lowest: compounds 1, 2, 3 and 4 (each within the scatter of the next).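

In this assay the read-out shows no change at the digits printed from compound 3 to compound 4 (within the scatter) when cyclohexyl replaces the hydrogen on this amine nitrogen. For the compounds shown here, the earlier compounds all carry hydrogen there, so this is the first sign that the nitrogen can bear a six-membered carbon ring while the maximal response holds. Nothing available here accounts for this result.

Going by these compounds, whether methyl, phenyl or a longer chain on this nitrogen would also hold the response stays open. So does whether cyclohexyl would behave the same way on compound 1 or compound 2.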